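Dropping the Chloro Group: Expected Cytotoxicity of Compound 4

The compounds below may be only part of what the source reports. "The series", "measured", "known", "first", "only" and "open" are said of these compounds alone.

Compound 1, `Cc1nnc(SCC(=O)N/N=c2/scc(-c3ccccc3)n2-c2ccccc2)s1`, in a functional assay on C6 cells (Rattus norvegicus) for cytotoxicity, read by MTT assay, with a stated time of 24 h, tested at 200 ug/mL (a higher number here means a weaker effect of the compound at the concentration tested, a lower number a stronger effect), gives 59.2%.
Compound 2, `O=C(CSc1nnnn1-c1ccccc1)N/N=c1/scc(-c2ccc(Br)cc2)n1-c1ccccc1`, in this assay gives 20.4%.
Compound 3, `O=C(CSc1nnnn1-c1ccccc1)N/N=c1/scc(-c2ccc(Cl)cc2)n1-c1ccccc1`, in this assay gives 52.4%.

Among these three numbers, compound 3 stands second highest; compound 1 lies within the usual scatter of it, while compound 2 sits far lower, beyond the scatter. Among the measured compounds shown here, the one step that can be compared directly, a number 32 percentage points higher from compound 2 to compound 3 (beyond the scatter), shows that exchanging one halogen for another on the outer ring moved the read-out by a large amount.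

Compound 4, `O=C(CSc1nnnn1-c1ccccc1)N/N=c1/scc(-c2ccccc2)n1-c1ccccc1`, differs from compound 3 by hydrogen in place of chloro on an aromatic carbon. For the measured compounds named here, no measured pair shows exactly this change. Compound 1 carries the same plain phenyl ring but a different thioether part, and its value lies within the scatter of compound 3, which gives weak support that removing the chloro leaves the read-out close to where compound 3 lies. The large step from bromo to chloro warns that changes on this ring can matter, so the range is kept wide. For compound 4 the expected step of a number 4.6 percentage points higher from compound 3 to compound 4 (within the scatter) is small, within the scatter. Compound 4 is therefore estimated at 57%, with a range from 35% to 80%.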

Compound 4, a percentage reported as activity, at one concentration (the size of the read-out at that concentration, not a potency): 22.6%
Compound 4: middle estimate off by 34.4 percentage points, on the high side; the measured number lies below the stated range.
By their numbers in this assay, from the lowest: compounds 2 and 4 (each within the scatter of the next); then compounds 3 and 1 (each within the scatter of the next).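

In this assay, where a lower number means a stronger effect, hydrogen in place of chloro on the outer ring gives a number 29.8 percentage points lower from compound 3 to compound 4 (beyond the scatter) and shows that this one atom matters at this place, para to a large group. Hydrogen in place of bromo gives a number 2.2 percentage points higher from compound 2 to compound 4 (within the scatter) and so puts the bromo and plain phenyl compounds together, with the chloro compound apart; among these three the read-out does not run in a simple order from hydrogen through chloro to bromo. The far end of the molecule matters as well, since with the plain phenyl ring kept, 1-phenyl-1H-tetrazol-5-yl in place of 5-methyl-1,3,4-thiadiazol-2-yl on the sulfur gives a number 36.6 percentage points lower from compound 1 to compound 4 (beyond the scatter) and one thioether part cannot stand in for the other.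

Still open, going by these compounds, is whether a fluoro, methoxy or amino group at this place would side with chloro or with bromo and hydrogen, and whether chloro would behave the same way with the 5-methyl-1,3,4-thiadiazol-2-yl group on the sulfur. Nothing at hand accounts for why chloro stands apart from hydrogen and bromo.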